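Phenyl sulfone in place of dimethylsulfonamide

A few compounds are considered here, and "the series" means these few. Any claim that something is new, unique, unknown or untested is made for them only; others in the source may bear on it.

Compound 2 `CN(C)S(=O)(=O)c1ccc(NC(=O)NCc2ccncc2)cc1` gives 3110 nM in an assay on isolated protein for activation of Nicotinamide phosphoribosyltransferase (Homo sapiens) (a lower number here means that less compound is needed, a higher number that more compound is needed for the effect), the higher of the two numbers recorded; compound 1 `O=C(NCc1cnco1)Nc1ccc(S(=O)(=O)c2ccccc2)cc1` gives 77 nM in this assay, a gap beyond the scatter. Compound 3 `O=C(NCc1ccncc1)Nc1ccc(S(=O)(=O)c2ccccc2)cc1` differs from compound 2 by phenyl in place of dimethylamino on a sulfonyl sulfur, which brings in the sulfone of compound 1. A sizeable step downward is expected, a 21-fold lower number from compound 2 to compound 3 (1.32 log units; beyond the scatter), since compound 1 with the same sulfone shows 77 nM. For compound 3 the expected value in this assay is 150 nM, within a range from 40 nM to 600 nM.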

Compound 3, half-maximal effective concentration: 85 nM
Compound 3: the middle estimate sits 1.8-fold (0.25 log units) above what was measured; the measured number falls inside the stated range.
By their numbers in this assay, from the lowest: compounds 1 and 3 (each within the scatter of the next); then compound 2.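

On the sulfonyl sulfur, phenyl in place of dimethylamino gives a 37-fold lower number from compound 2 to compound 3 (1.56 log units; beyond the scatter) in this assay with the rest of compound 2 unchanged, which ties the gain directly to this position. With the phenyl sulfone in place, pyridin-4-yl in place of 1,3-oxazol-5-yl on the saturated chain carbon gives a 1.1-fold higher number from compound 1 to compound 3 (0.04 log units; within the scatter) and so makes no difference that can be read. No measurement here gives a reason for either step.

Going by these compounds, whether a cyclohexyl or a piperidine on the sulfonyl sulfur would hold the number near that of compound 3 stays open. Also open, on these data alone, is whether the step from dimethylamino to phenyl keeps its size with 1,3-oxazol-5-yl on the chain.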